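Replacing a Ring Hydrogen on Compound 1 with a Larger Group

The source may hold more compounds than are shown below. What is called first, only, known or untested is meant among the compounds shown, and "the series" means these compounds.

Measured in a functional assay on BT-549 cells (Homo sapiens) for cytotoxicity, read by sulforhodamine B assay, with a stated time of 48 h; on this read-out higher numbers stand for weaker inhibition of growth and lower numbers for stronger inhibition of growth:
compound 1 `Cn1cccc1-c1cc(-c2ccc(Br)cc2)[nH]c(=O)c1C#N` gives 85100 nM.
compound 2 `COc1ccc(-c2cc(-c3cccn3C)c(C#N)c(=O)[nH]2)cc1OC` gives only a limit of the assay, > 100000 nM.
compound 3 `COc1ccc(-c2cc(-c3cccs3)[nH]c(=O)c2C#N)cc1` gives only a limit of the assay, > 100000 nM.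

Among the compounds with values here, compound 1 therefore holds the only real number among the three; the other two sit at the limit of > 100000 nM in this assay, at which 2 of the 3 values shown sit. Compound 4 `Cn1cccc1-c1cc(-c2ccc(Br)cc2)n(C(=S)Nc2ccc(F)cc2)c(=O)c1C#N` carries a group of 10 heavy atoms (7 carbon, 1 nitrogen, 1 fluorine, 1 sulfur; one six-membered aromatic ring of carbon only) in place of a hydrogen atom, on an aromatic nitrogen. Within the data shown here, no pair of measured compounds that differ in one place is available, so no measured step gives a size to lean on. For the step from compound 1 to compound 4 a moderate move toward stronger inhibition of growth is expected, a 2.1-fold lower number from compound 1 to compound 4 (0.33 log units; beyond the scatter). Compound 4 is accordingly estimated at 40000 nM, with a plausible range from 8000 nM to 100000 nM.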

Compound 4, concentration for 50% growth inhibition: > 100000 nM
Compound 4: only a limit was reported; the forecaster's own chance of this, stated with the estimate: 25%; at least 2.5-fold (0.39 log units) between middle value and limit.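

Placing this large group on the aromatic nitrogen of compound 1 brings no visible gain in growth inhibition: compound 4 gives only a limit of the assay in this assay. The step reads as an at least 1.1-fold higher number from compound 1 to compound 4 (0.07 log units; that floor lies within the scatter), so any loss of activity has no known size. Compound 4 thus adds no real number to the series: the limit of > 100000 nM in this assay, at which 3 of the 4 values shown sit.

Going by these compounds, whether an ethyl or acetyl group on the same nitrogen would keep or strengthen inhibition stays open. So does the part played by the fluorine atom within the group on compound 4.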